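From 4-chlorobenzyl to 3-azido-4-methoxybenzyl

A few compounds are considered here, and "the series" means these few. Any claim that something is new, unique, unknown or untested is made for them only; others in the source may bear on it.

In a functional assay on HCT-116 cells (Homo sapiens) for inhibition, read by CCK-8 assay, with a stated time of 48 h (on this read-out higher numbers stand for weaker inhibition and lower numbers for stronger inhibition), compound 1 (`COc1ccc(CN(C(=O)CSC(=S)N2CCN(C(=O)OC(C)(C)C)CC2)c2ccccc2)cc1`) reads > 20000 nM, which is a limit and not a number. Compound 2 (`COc1ccc(CN(C(=O)CSC(=S)N2CCN(C(=O)OC(C)(C)C)CC2)c2ccc(OC)cc2)cc1`) reads > 20000 nM, again a limit. Within the data shown here, compound 3 (`COc1cc(N(Cc2ccc(Cl)cc2)C(=O)CSC(=S)N2CCN(C(=O)OC(C)(C)C)CC2)cc(OC)c1OC`) gives 8490 nM, the only true number so far. The rest of the picture is the limit of > 20000 nM in this assay, at which 2 of the 3 values shown sit. Among the measured compounds shown here, the one measured step is a step that the two limits leave unreadable from compound 1 to compound 2, so it offers no size to carry forward.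

Compound 4 (`COc1ccc(CN(C(=O)CSC(=S)N2CCN(C(=O)OC(C)(C)C)CC2)c2cc(OC)c(OC)c(OC)c2)cc1N=[N+]=[N-]`) keeps the rest of compound 3 and changes one group: 3-azido-4-methoxyphenyl in place of 4-chlorophenyl on a saturated chain carbon bound to an amide-type nitrogen. In words, 4-chlorobenzyl gives way to 3-azido-4-methoxybenzyl. For the measured compounds named here, no measured step covers this swap, so any forecast is loose. The two compounds at the limit both carry a methoxy on this benzyl, and compound 4 has one too, which tilts the expectation slightly towards weaker inhibition in this assay. The expected change is a 1.4-fold higher number from compound 3 to compound 4 (0.15 log units; within the scatter), a step that may stay within the scatter. For compound 4 the estimated value is 12000 nM, with an expected range of 4000 nM to 20000 nM.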

Compound 4, half-maximal inhibitory concentration: 780 nM
Estimate against measurement, compound 4: 15-fold (1.19 log units) above, outside the stated range (below it).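

In this assay, replacing 4-chlorophenyl with 3-azido-4-methoxyphenyl on a saturated chain carbon bound to an amide-type nitrogen gives an 11-fold lower number from compound 3 to compound 4 (1.04 log units; beyond the scatter) and so shows that inhibition responds strongly to the group at this place. Among these compounds, this is the first step with a readable size, as the earlier step between two limits could not be read. The new value also matters against a background in which much of the series gives no true number: the limit of > 20000 nM in this assay, at which 2 of the 4 values shown sit.

The azido and methoxy groups enter together, so this step cannot show whether one of them accounts for the change or both are needed. It also leaves open how a benzyl group carrying an amine in place of the azido group would read.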